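The source may report more compounds than this note shows. Statements on the series, on what has been measured and on what is new or still open speak of the compounds shown alone.

Compound 1 `O=c1cc(-c2ccccc2)oc2cccc(OCCCN3CCC(O)CC3)c12` gave 125 nM in an assay on isolated protein (Cavia porcellus) with Sigma non-opioid intracellular receptor 1 (Homo sapiens) as the target, read by radioligand binding; on this read-out lower numbers stand for stronger inhibition and higher numbers for weaker inhibition. Compound 2 `O=c1cc(-c2ccccc2)oc2cccc(OCCCCN3CCC(O)CC3)c12` gave 58 nM in this assay.

Going by the values given here, of these two numbers compound 2 has the lower one, and its only neighbour is compound 1: the step went to a lower number, a 2.2-fold lower number from compound 1 to compound 2 (0.33 log units; beyond the scatter), when the chain between the aromatic oxygen and the hydroxypiperidine ring was lengthened. Compound 3 `O=c1cc(-c2ccccc2)oc2cccc(OCCCCCCCN3CCC(O)CC3)c12` lengthens that same chain further: 3-(4-hydroxypiperidin-1-yl)propyl in place of 4-hydroxypiperidin-1-yl on a saturated chain carbon, four bonds along the chain from an oxygen on an aromatic ring. Among the compounds with values here, the only measured step that bears on this is the one from compound 1 to compound 2, which was modest and in the direction of a lower number. Stretching the chain again might continue that trend, but a longer chain could equally reach a point where the number no longer falls, so a small further lowering, or none beyond the scatter, is expected in this assay. For compound 3 the estimate is 35 nM, with a range from 12 nM to 120 nM. This estimate corresponds to an expected step of a 1.7-fold lower number from compound 2 to compound 3 (0.22 log units; within the scatter).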

Compound 3, half-maximal inhibitory concentration: 36 nM
Compound 3: middle estimate off by 1.0-fold (0.01 log units), on the low side, within the range that was stated.
By their numbers in this assay, from the lowest: compounds 3 and 2 (each within the scatter of the next); then compound 1.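

Replacing 4-hydroxypiperidin-1-yl with 3-(4-hydroxypiperidin-1-yl)propyl at this place on the saturated chain gives a 1.6-fold lower number from compound 2 to compound 3 (0.21 log units; within the scatter) in this assay, so the two compounds cannot be told apart here. The earlier lengthening, a 2.2-fold lower number from compound 1 to compound 2 (0.33 log units; beyond the scatter), lay beyond the scatter, so the clear change seen at that shorter chain does not show up again at this step, and this much larger group keeps the number within the scatter of the one before it. Nothing available explains why these two steps read differently.

The compounds shown leave open whether a longer chain would hold this level or lose it. They also leave open how much the hydroxyl counts at this chain length, which a carboxylic acid in its place or a morpholine ring instead of the hydroxypiperidine would test.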